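Furan-2-yl in place of benzofuran-2-yl on the pyrimidinone core

The source may hold more compounds than are shown below. What is called first, only, known or untested is meant among the compounds shown, and "the series" means these compounds.

Working notes on a small set of nucleoside analogues tested in a functional assay on HeLa S3 cells (Homo sapiens) for antiproliferative activity, read by XTT assay, with a stated time of 72 h; a higher number here means a weaker inhibitor, a lower number a stronger inhibitor. Compound 2 `O=c1[nH]cnc2c1c(-c1cc3ccccc3o1)cn2[C@@H]1O[C@H](CO)[C@@H](O)[C@H]1O` reaches only the limit of this assay, giving > 20000 nM. Compound 1 `Nc1nc2c(c(-c3ccccc3)cn2[C@@H]2O[C@H](CO)[C@@H](O)[C@H]2O)c(=O)[nH]1` likewise gives only the limit, > 20000 nM. Compound 3 `COc1ncnc2c1c(-c1ccoc1)cn2[C@@H]1O[C@H](CO)[C@@H](O)[C@H]1O`, on a different core, gives a measured 1790 nM. Compound 2 thus stands at the limit of > 20000 nM in this assay, at which 2 of the 3 values shown sit, together with compound 1. Compound 4 `O=c1[nH]cnc2c1c(-c1ccco1)cn2[C@@H]1O[C@H](CO)[C@@H](O)[C@H]1O` differs from compound 2 by furan-2-yl in place of 1-benzofuran-2-yl on an aromatic carbon. Within the data shown here, no measured pair here isolates this change, so the direction of the step is open; a move within the scatter or a modest gain is expected, and the expected step is an at least 1.3-fold lower number from compound 2 to compound 4 (0.12 log units; that floor lies within the scatter). Compound 4 is estimated at 15000 nM, in the range 4000 nM to 60000 nM.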

Compound 4, half-maximal inhibitory concentration: 5780 nM
Compound 4: middle estimate off by 2.6-fold (0.41 log units), on the high side, within the range that was stated.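

In this assay, furan-2-yl in place of 1-benzofuran-2-yl on this aromatic carbon gives an at least 3.4-fold lower number from compound 2 to compound 4 (0.53 log units; beyond the scatter). The shared core of compound 2 and compound 4 therefore gives a measured value when this position carries furan-2-yl. The step is only a floor, because compound 2 gives no number: the limit of > 20000 nM in this assay, at which 2 of the 4 values shown sit.

Whether the fused six-membered aromatic ring alone accounts for the step remains open, as does the outcome with thiophen-2-yl or an amine on this carbon. Among these compounds, compound 1 and compound 3 differ from compound 4 in more than one place, so no step to either can be read.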